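Amino for Hydroxy on a Phenylethynyl Nucleoside

A few compounds are considered here, and "the series" means these few. Any claim that something is new, unique, unknown or untested is made for them only; others in the source may bear on it.

Compound 1 `CCCC#Cc1cn([C@@H]2O[C@H](CO)[C@@H](O)[C@H](O)[C@H]2O)c(=O)nc1N`: 191000 nM
Compound 2 `CCCCCC#Cc1cn([C@@H]2O[C@H](CO)[C@@H](O)[C@H](O)[C@H]2O)c(=O)nc1N`: a limit, >= 250000 nM
Compound 3 `O=c1nc(O)c(C#Cc2ccccc2)cn1[C@@H]1O[C@H](CO)[C@@H](O)[C@H](O)[C@H]1O`: 5400 nM

In a functional assay on HeLa cells (Homo sapiens) for cytotoxicity, with a stated time of 72 h (on this read-out higher numbers stand for weaker inhibition and lower numbers for stronger inhibition), compound 3 gives the lowest of the numbers shown. Compound 1 sits higher, and for compound 2 this assay reports only a limit, at the limit of >= 250000 nM in this assay, at which 1 of the 3 values shown sits. Among the measured compounds shown here, the one measured step, an at least 1.3-fold higher number from compound 1 to compound 2 (0.11 log units; that floor lies within the scatter), concerns an alkyl chain and not the pyrimidine ring. Compound 4 `Nc1nc(=O)n([C@@H]2O[C@H](CO)[C@@H](O)[C@H](O)[C@H]2O)cc1C#Cc1ccccc1` differs from compound 3 by amino in place of hydroxy on an aromatic carbon. For the measured compounds named here, no measured step bears on this change, so no direction beyond the scatter can be drawn from the data. For compound 4 a number near that of compound 3 is expected, 8000 nM, within 1500 nM to 60000 nM, with a step of a 1.5-fold higher number from compound 3 to compound 4 (0.17 log units; within the scatter) estimated.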

Compound 4, half-maximal inhibitory concentration: 201000 nM
For compound 4 the middle estimate is 25-fold (1.40 log units) below the measured one, and the stated range ends below it.
By their numbers in this assay, from the lowest: compound 3; then compounds 1 and 4 (each within the scatter of the next). At a limit, above all of these: compound 2.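

On the aromatic carbon opposite the ring nitrogen, amino in place of hydroxy proves a large change in this assay: a 37-fold higher number from compound 3 to compound 4 (1.57 log units; beyond the scatter). With amino there, phenyl in place of propyl on the triple-bonded carbon gives no separation beyond the scatter: a 1.1-fold higher number from compound 1 to compound 4 (0.02 log units; within the scatter). The step for phenyl in place of pentyl starts from a limit and reads only as a floor: an at least 1.2-fold lower number from compound 2 to compound 4 (0.09 log units; that floor lies within the scatter).

Nothing given here accounts for the large step. From the compounds shown here alone, whether methoxy or methylamino on that carbon would sit nearer compound 3 or compound 4 stays open, as does hydroxy paired with a propyl or pentyl chain.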